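This account rests on a few compounds, and the source may have more. Where it says the series, first, only, none or still open, it means among the compounds named here.

Among the measured compounds shown here, compound 2 `COc1ccc(-c2oc3c(CNCc4cccc(F)c4)c(O)ccc3c(=O)c2O)c(OC)c1` gives 19% in a functional assay on RPMI-8226 cells (Homo sapiens) for inhibition, read by CCK-8 assay, with a stated time of 72 h, tested at 125 uM (a lower number here means less inhibition, a higher number more inhibition at the concentration tested (going by the name of the read-out)), the lowest of the two numbers measured so far; compound 1 `O=C(O)[C@@H]1CCCN1Cc1c(O)ccc2c(=O)c(O)c(-c3cccc(Cl)c3Cl)oc12` gives 49%, a gap beyond the scatter, but the two structures differ in more than one place, so no single change is isolated by that pair. Compound 3 `CCN(CC)Cc1c(O)ccc2c(=O)c(O)c(-c3ccc(OC)cc3OC)oc12` is compound 2 with diethylamino in place of (3-fluorobenzyl)amino on a saturated chain carbon bound to an aromatic carbon. For the measured compounds named here, no measured pair tracks this change, so for compound 3 the expected step is a number 3 percentage points higher from compound 2 to compound 3 (within the scatter), taken as lying within the scatter with no direction assumed. Compound 3 is accordingly estimated at 22% in this assay, ranging from 5% to 45%.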

Compound 3, a percentage reported as inhibition, at one concentration (the size of the read-out at that concentration, not a potency): 25%
Compound 3: the middle estimate sits 3 percentage points below what was measured; the range from low to high includes it.
By their numbers in this assay, from the lowest: compounds 2 and 3 (each within the scatter of the next); then compound 1.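

In this assay, among the compounds shown here, diethylamino in place of (3-fluorobenzyl)amino on a saturated chain carbon bound to an aromatic carbon gives a number 6 percentage points higher from compound 2 to compound 3 (within the scatter) in the first single-place comparison of the series. At this place, the aromatic ring of the leaving group can therefore go without a change beyond the scatter at the tested concentration. No supporting measurement bears on this outcome.

As far as these compounds go, whether a morpholine or a piperazine at this place would give a different number remains open. What separates compound 1 from compound 2 also remains unresolved, as those structures differ in more than one place.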